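From 3-methylpyridin-4-yl to 4-methylpyridin-3-yl at one chain carbon

This account rests on a few compounds, and the source may have more. Where it says the series, first, only, none or still open, it means among the compounds named here.

Measured in a functional assay on MCF7 cells (Homo sapiens) for cytotoxicity, read by CellTiter-Glo, with a stated time of 5 days; a higher number here means a weaker inhibitor, a lower number a stronger inhibitor:
- compound 1 `CC/C(=C(/c1ccc(/C=C/C(=O)O)cc1)c1ccc2[nH]ncc2c1)c1cccc(Cl)c1`: 12 nM
- compound 2 `CC/C(=C(/c1ccc(/C=C/C(=O)O)cc1)c1ccc2[nH]ncc2c1)c1ccccc1C#N`: 12 nM
- compound 3 `CC/C(=C(/c1ccc(/C=C/C(=O)O)cc1)c1ccc2[nH]ncc2c1)c1ccncc1C`: 16 nM

Compound 3 cannot be told apart from the other two compounds. The nearest evidence is a 1.3-fold higher number from compound 1 to compound 3 (0.12 log units; within the scatter) and a 1.3-fold higher number from compound 2 to compound 3 (0.12 log units; within the scatter), and the remaining swap gave no change at the digits printed from compound 1 to compound 2 (within the scatter).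

Compound 4 `CC/C(=C(/c1ccc(/C=C/C(=O)O)cc1)c1ccc2[nH]ncc2c1)c1cnccc1C` has the same atoms, joined differently: 4-methylpyridin-3-yl in place of 3-methylpyridin-4-yl on a double-bonded chain carbon bound to a double-bonded chain carbon and a saturated chain carbon. None of the three measured swaps at this place left the scatter, so no real shift is expected in this assay. The expected step is a 1.1-fold lower number from compound 3 to compound 4 (0.03 log units; within the scatter). Compound 4 is estimated at 15 nM, with an expected range of 6 nM to 35 nM.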

Compound 4, half-maximal inhibitory concentration: 150 nM
The estimate for compound 4 lay 10-fold (1.00 log units) below the measured number, outside the stated range (above it).
By their numbers in this assay, from the lowest: compounds 1, 2 and 3 (each within the scatter of the next); then compound 4.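

Exchanging 3-methylpyridin-4-yl for 4-methylpyridin-3-yl, the same atoms joined differently, gives a 9.4-fold higher number from compound 3 to compound 4 (0.97 log units; beyond the scatter) in this assay, so this position responds to the arrangement within the ring even though the earlier swaps there stayed within the scatter. Compound 4 also stands apart from the two benzene-ring compounds, with a 13-fold higher number from compound 2 to compound 4 (1.10 log units; beyond the scatter) and a 13-fold higher number from compound 1 to compound 4 (1.10 log units; beyond the scatter). Nothing available here explains this loss. As far as these compounds go, whether it follows the ring nitrogen or the methyl remains open, and plain pyridin-3-yl and 4-methylphenyl groups at this place would help separate the two.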